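This account rests on a few compounds, and the source may have more. Where it says the series, first, only, none or still open, it means among the compounds named here.

Measured so far:
compound 1, `CCCCCOc1ccc2[nH]c(-c3ccc(OC)cc3)c(C3=C(Br)C(=O)NC3=O)c2c1`: 3.77
compound 2, `CCCCCCOc1ccc2[nH]c(-c3ccc(OC)cc3)c(C3=C(Br)C(=O)NC3=O)c2c1`: 4.1
compound 3, `COc1cccc(-c2[nH]c3ccc(OC)cc3c2C2=C(Br)C(=O)NC2=O)c1`: 2.79

These three values come from a physicochemical assay for lipophilicity; on this read-out lower numbers stand for lower lipophilicity and higher numbers for higher lipophilicity. Compound 4, `CCOc1ccc2[nH]c(-c3cccc(OC)c3)c(C3=C(Br)C(=O)NC3=O)c2c1`, has not yet been measured in this assay.

Compound 1 and compound 2 differ in one place, (methyl in place of hydrogen on a saturated chain carbon, five bonds along the chain from an oxygen on an aromatic ring), and that change made a step of a number 0.33 log units higher from compound 1 to compound 2 (beyond the scatter).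

The difference between the core of compound 1 and the core of compound 3 is not broken down here; compound 3 gives the lowest of the three values, sitting below compound 1 and compound 2 beyond the scatter.

Compound 3 and compound 4 differ in one place, (methyl in place of hydrogen on a saturated chain carbon bound to an oxygen on an aromatic ring). Among the measured compounds shown here, this is the same kind of change as the one from compound 1 to compound 2, but not the same: in compound 4 the new methyl sits on a saturated chain carbon bound to an oxygen on an aromatic ring, whereas in compound 2 it sits five bonds along the chain from an oxygen on an aromatic ring. A step of roughly the same size is expected here, a number 0.41 log units higher from compound 3 to compound 4 (beyond the scatter), resting on the step of a number 0.33 log units higher from compound 1 to compound 2 (beyond the scatter) seen for the same kind of change. Compound 4 is therefore estimated at 3.2 in this assay, most likely between 2.9 and 3.55.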

Compound 4, partition coefficient: 2.97
Compound 4: middle estimate off by 0.23 log units, on the high side; low and high end bracket the measured number.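

In this assay, the change from methoxy to ethoxy gives a number 0.18 log units higher from compound 3 to compound 4 (within the scatter), while the methyl placed five bonds along the chain from an oxygen on an aromatic ring, on the other core, gave a number 0.33 log units higher from compound 1 to compound 2 (beyond the scatter). This shows that a step beyond the scatter on one core did not reappear as a clear step in this single pair, but it does not show that the change fails to carry over, since the new methyl sits at a different place in each pair and the core differs as well, leaving those two differences impossible to separate. Nothing measured here bears on the reason for this result.

The compounds shown leave open what the same methoxy to ethoxy change would do on the core of compound 1, where it could be compared directly with this pair. They also leave open how a longer chain such as propoxy, or an amine or a carboxylic acid carried on the chain, would read on the core of compound 4.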